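Sulfonamide aryl variation: methoxyphenyl to methylphenyl

The source may report more compounds than this note shows. Statements on the series, on what has been measured and on what is new or still open speak of the compounds shown alone.

The compounds share one core and differ only in the aryl group on the sulfonamide nitrogen. In a functional assay on M21 cells (Homo sapiens) for antiproliferative activity, read by sulforhodamine B assay, with a stated time of 48 h (on this read-out lower numbers stand for stronger inhibition and higher numbers for weaker inhibition), compound 2 `COc1ccccc1NS(=O)(=O)c1ccc(N2CCNC2=O)cc1` gives 300 nM. That is the highest of the two numbers in this assay; the nearest measured neighbour is compound 3 `O=C1NCCN1c1ccc(S(=O)(=O)Nc2cccc(Cl)c2)cc1`, which gives 25 nM. Compound 1 `CC(C)Cc1ccc(NS(=O)(=O)c2ccc(N3CCNC3=O)cc2)cc1` gives only a limit of the assay, > 1000 nM. Compound 4 `Cc1ccc(NS(=O)(=O)c2ccc(N3CCNC3=O)cc2)cc1` is not yet measured.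

The change from compound 2 to compound 4 is 4-methylphenyl in place of 2-methoxyphenyl on a sulfonamide nitrogen. For the measured compounds named here, the only measured step on this nitrogen is a 12-fold lower number from compound 2 to compound 3 (1.08 log units; beyond the scatter), which shows that the aryl group here can move the number well beyond the scatter. That step, however, brings in a different group from the one entering here, so it sets no direction for compound 4. The limit noted for compound 1 the limit of > 1000 nM in this assay, at which 1 of the 3 values shown sits, also involves a different group.

Going by the values given here, with no directly comparable step, a change within the scatter or modestly beyond it is expected. The estimate for compound 4 is 400 nM, with a range from 100 nM to 2000 nM. This corresponds to an expected step of a 1.3-fold higher number from compound 2 to compound 4 (0.12 log units; within the scatter).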

Compound 4, half-maximal inhibitory concentration: 260 nM
Beside the measured number, compound 4's estimate is 1.5-fold (0.19 log units) above it; low and high end bracket the measured number.
By their numbers in this assay, from the lowest: compound 3; then compounds 4 and 2 (each within the scatter of the next). At a limit, above all of these: compound 1.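

In this assay, 4-methylphenyl in place of 2-methoxyphenyl on the sulfonamide nitrogen gives a 1.2-fold lower number from compound 2 to compound 4 (0.06 log units; within the scatter), so the two groups are not told apart here, although the hydrogen-bond acceptor of 2-methoxyphenyl is absent from 4-methylphenyl. Against 3-chlorophenyl the same group gives a 10-fold higher number from compound 3 to compound 4 (1.02 log units; beyond the scatter), which sets compound 3 apart from both compound 2 and compound 4. Hydrogen in place of isopropyl on the saturated chain carbon gives an at least 3.8-fold lower number from compound 1 to compound 4 (0.58 log units; beyond the scatter), a step bounded on one side only, since compound 1 stands at a limit: the limit of > 1000 nM in this assay, at which 1 of the 4 values shown sits.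

Still open, as far as these compounds go, is whether the chlorine itself or its place on the ring goes with the low number of compound 3. Also open, from the compounds shown here alone, is how 3-methylphenyl, 3-methoxyphenyl, or an aryl group bearing an amine or a carboxylic acid would read on this nitrogen.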